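The source may report more compounds than this note shows. Statements on the series, on what has been measured and on what is new or still open speak of the compounds shown alone.

Compound 1 `C=CC1=C(C(=O)NCc2ccc(Cl)cc2)C(c2ccc(OC)c(OC)c2)OC1` in a functional assay on HeLa cells (Homo sapiens) for cytotoxicity, read by MTT assay, with a stated time of 24 h (on this read-out higher numbers stand for weaker inhibition and lower numbers for stronger inhibition), gives > 100000 nM, which is a limit of the assay. Compound 2 `C=CC1=C(C(=O)NCc2ccc(Cl)cc2)C(c2ccc(OC)cc2)OC1` in this assay gives > 100000 nM, again a limit. Compound 3 `C=CC1=C(C(=O)NCc2ccccc2)C(c2ccc(Cl)c(Cl)c2)OC1` in this assay gives > 100000 nM, also a limit.

Compound 2 thus stands at the limit of > 100000 nM in this assay, at which 3 of the 3 values shown sit, with nothing to separate it from the others. Within the data shown here, the only single-point step, a step that the two limits leave unreadable from compound 1 to compound 2, changes the aromatic ring rather than the amide and so does not bear on the present change, (4-methylphenyl in place of 4-chlorobenzyl on an amide-type nitrogen), which yields compound 4 `C=CC1=C(C(=O)Nc2ccc(C)cc2)C(c2ccc(OC)cc2)OC1`. Among the measured compounds shown here, no measured step speaks to this position, so no step beyond the scatter is expected, a step that the limit leaves unreadable from compound 2 to compound 4. Compound 4 is estimated at 150000 nM, between 40000 nM and 600000 nM, most likely reported as a limit.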

Compound 4, half-maximal inhibitory concentration: > 100000 nM
Compound 4 was reported as a limit (the forecaster's own chance of this, stated with the estimate: 75%); the middle value lies beyond the limit too.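

Compound 2 and compound 4 each give only a limit, so no step can be read between them: the limit of > 100000 nM in this assay, at which 4 of the 4 values shown sit.

The compounds shown leave open which change to the shared core, if any, would give a readable value in this assay.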